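The compounds below may be only part of what the source reports. "The series", "measured", "known", "first", "only" and "open" are said of these compounds alone.

Measured so far:
Compound 1 `C#CCOC(=O)/C(C)=C/CC/C(C)=C/CC/C(C)=C/CC[C@@H]1[C@@]2(C)CCC(=O)C(C)(C)[C@H]2CC[C@@]1(C)O` gives 45100 nM in a functional assay on A549 cells (Homo sapiens) for antiproliferative activity, read by MTT assay, with a stated time of 48 h; a lower number here means a stronger inhibitor, a higher number a weaker inhibitor.
Compound 2 `C/C(=C\CC/C(C)=C/CC[C@@H]1[C@@]2(C)CCC(=O)C(C)(C)[C@H]2CC[C@@]1(C)O)CC/C=C(\C)C(=O)OCc1cn(-c2ccc([N+](=O)[O-])cc2)nn1` reaches only a limit in this assay, namely > 150000 nM.

Compound 2 therefore stands at the weaker end of what is shown; its number is not a value but the limit of this assay, as noted in the limit of > 150000 nM in this assay, at which 1 of the 2 values shown sits. Within the data shown here, compound 1 does return a number, but compound 1 and compound 2 differ in more than one place, so their two values are only set side by side here and no step between them is drawn.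

Compound 3 `C/C(=C\CC/C(C)=C/CC[C@@H]1[C@@]2(C)CCC(=O)C(C)(C)[C@H]2CC[C@@]1(C)O)CC/C=C(\C)C(=O)OCc1cn(-c2ccc(C)cc2)nn1` is the unmeasured partner of compound 2. The change is methyl in place of nitro on an aromatic carbon, a methyl in place of nitro on an aromatic carbon, para to a large group. No measured step of this kind exists among the compounds shown. Given that compound 2 sits at the limit (the limit of > 150000 nM in this assay, at which 1 of the 2 values shown sits), the step is expected to be small, within the scatter, as an at least 1.1-fold lower number from compound 2 to compound 3 (0.06 log units; that floor lies within the scatter). Compound 3 is thus estimated at 130000 nM, between 50000 nM and 330000 nM.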

Compound 3, half-maximal inhibitory concentration: > 150000 nM
Compound 3 was reported as a limit (the forecaster's own chance of this, stated with the estimate: 45%); middle value at least 1.1-fold (0.06 log units) from the limit.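

In this assay compound 3 gives > 150000 nM, which is a limit of the assay and not a number. Among these compounds, this provides the first readable step: 1-(4-methylphenyl)-1H-1,2,3-triazol-4-yl in place of ethynyl gives an at least 3.3-fold higher number from compound 1 to compound 3 (0.52 log units; beyond the scatter), which lies beyond the scatter and shows that this change at the ester end costs activity. The step from nitro to methyl on the aromatic carbon cannot be read, so the two aryl groups cannot be ranked: the limit of > 150000 nM in this assay, at which 2 of the 3 values shown sit.

As far as these compounds go, it remains open how far past the limit compound 2 and compound 3 lie. From the compounds shown here alone, it is also open whether an amine on that aromatic carbon, or a short alkyl chain in place of the 4-methylphenyl group, would return a number in this assay.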